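This account rests on a few compounds, and the source may have more. Where it says the series, first, only, none or still open, it means among the compounds named here.

Measured in a functional assay on HCC827 cells (Homo sapiens) for inhibition, read by MTT assay, with a stated time of 48 h, tested at 10 uM; a higher number here means more inhibition at the concentration tested (going by the name of the read-out), a lower number less inhibition:
compound 1 `COc1cc(NC(=O)Nc2cc(Nc3ccc(C)c(C)c3)ncn2)cc(OC)c1` gives 45.7%
compound 2 `COc1cc(Br)ccc1Nc1cc(NC(=O)Nc2c(Cl)cccc2Cl)ncn1` gives 42.7%
compound 3 `COc1ccc(Br)cc1Nc1cc(NC(=O)Nc2c(Cl)cccc2Cl)ncn1` gives 53%

Compound 1 stands second highest of the three numbers, within the scatter of both compound 2 and compound 3. Going by the values given here, the one step that goes beyond the scatter, a number 10.3 percentage points higher from compound 2 to compound 3 (beyond the scatter), concerns the bromo-methoxyphenyl on the shared core and is modest.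

Compound 4 `CCc1cccc(Nc2cc(NC(=O)Nc3cc(OC)cc(OC)c3)ncn2)c1` differs from compound 1 by 3-ethylphenyl in place of 3,4-dimethylphenyl on a nitrogen on an aromatic ring. Among the compounds with values here, no measured step touches this group, so nothing bears on the change directly. Within the data shown here, with the same atoms joined differently and the one known step only modest, no step beyond the scatter is expected in this assay, in either direction, with a number 0.7 percentage points lower from compound 1 to compound 4 (within the scatter) as the expected step. Compound 4 is estimated at 45%, within 30% to 60%.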

Compound 4, a percentage reported as inhibition, at one concentration (the size of the read-out at that concentration, not a potency): 52.6%
Estimate against measurement, compound 4: 7.6 percentage points below, within the range that was stated.
By their numbers in this assay, from the lowest: compounds 2, 1, 4 and 3 (each within the scatter of the next, the first and the last beyond it).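

Going by these compounds alone, the change from 3,4-dimethylphenyl to 3-ethylphenyl on a nitrogen on an aromatic ring is the first measured at this position, and in this assay it gives a number 6.9 percentage points higher from compound 1 to compound 4 (within the scatter). Within this one pair, rearranging the same carbon atoms on the ring therefore leaves the read-out inside the usual scatter. Nothing measured here offers a reason for this result.

As far as these compounds go, whether the position accepts more than a carbon-only substituent remains open, for example an amine or a carboxylic acid on the ring. A propyl chain in place of the ethyl is equally unresolved.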